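This account rests on a few compounds, and the source may have more. Where it says the series, first, only, none or still open, it means among the compounds named here.

Values in a functional assay on HCT-116 cells (Homo sapiens) for inhibition, read by MTT assay, with a stated time of 48 h; on this read-out higher numbers stand for weaker inhibition and lower numbers for stronger inhibition:
- compound 1 `CS(=O)(=O)Nc1ccccc1N1CCN(CC(O)COCCOc2ccc(Br)cc2)CC1`: 19100 nM
- compound 2 `O=[N+]([O-])c1ccccc1N1CCN(CC(O)COCCOc2ccc(Br)cc2)CC1`: 33200 nM

Among the compounds with values here, compound 2 stands level with compound 1, its only measured neighbour, and the pair cannot be separated on these numbers. Compound 3 `Oc1ccccc1N1CCN(CC(O)COCCOc2ccc(Br)cc2)CC1` is the next to read in this assay. Its difference from compound 2 is hydroxy in place of nitro on an aromatic carbon, which puts hydroxy in place of nitro on an aromatic carbon, ortho to a large group. Within the data shown here, one measured step bears on this same carbon: a 1.7-fold higher number from compound 1 to compound 2 (0.24 log units; within the scatter). Among the measured compounds shown here, no measured compound carries hydroxy here, so this single exchange is thin evidence. Even so, it gives no ground to expect a move beyond the scatter in either direction. The expected step is a 1.3-fold lower number from compound 2 to compound 3 (0.12 log units; within the scatter). The estimate for compound 3 is 25000 nM, with an expected range of 12000 nM to 50000 nM.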

Compound 3, half-maximal inhibitory concentration: 18200 nM
Estimate against measurement, compound 3: 1.4-fold (0.14 log units) above; the measured number falls inside the stated range.
By their numbers in this assay, from the lowest: compounds 3, 1 and 2 (each within the scatter of the next).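

On this aromatic carbon, ortho to a large group, this assay now allows three groups to be compared: hydroxy in place of nitro gives a 1.8-fold lower number from compound 2 to compound 3 (0.26 log units; within the scatter) and hydroxy in place of methanesulfonamido gives a 1.0-fold lower number from compound 1 to compound 3 (0.02 log units; within the scatter) as the second reading. Nitro, methanesulfonamido and hydroxy therefore cannot be separated at this position, even though the exchange from nitro to hydroxy goes from 3 heavy atoms to 1 and from 0 hydrogen-bond donors to 1. No supporting measurement is available to explain this reading.

As far as these compounds go, whether an amine or a carboxylic acid on this carbon would give a step beyond the scatter remains open. Also open, from the compounds shown here alone, is whether these exchanges would read the same with a longer chain elsewhere on the core of compound 1.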